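An Ester in Place of the Cyclopentyl Group

The compounds below may be only part of what the source reports. "The series", "measured", "known", "first", "only" and "open" are said of these compounds alone.

Of the compounds shown here, three sharing one core have been measured in an assay on isolated protein for inhibition of tyrosine-protein kinase receptor UFO (Homo sapiens), read by FRET and Z'-LYTE, with a stated time of 1.5 h; on this read-out lower numbers stand for stronger inhibition and higher numbers for weaker inhibition. Compound 1 `Cc1c(C(=O)Nc2ccc(Oc3ncnc4[nH]cc(-c5ccccc5)c34)c(F)c2)c(=O)c2cc(C(C)C)ccc2n1C` gives 26 nM, compound 2 `C=C(C)c1ccc2c(c1)c(=O)c(C(=O)Nc1ccc(Oc3ncnc4[nH]cc(-c5ccccc5)c34)c(F)c1)c(C)n2C` gives 170 nM, and compound 3 `Cc1c(C(=O)Nc2ccc(Oc3ncnc4[nH]cc(-c5ccccc5)c34)c(F)c2)c(=O)c2cc(C3CCCC3)ccc2n1C` gives 200 nM, the highest of the three numbers; compound 2 sits within the scatter of compound 3, while compound 1 lies further off, as a 7.7-fold higher number from compound 1 to compound 3 (0.89 log units; beyond the scatter) and a 1.2-fold higher number from compound 2 to compound 3 (0.07 log units; within the scatter) show.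

Compound 4 `COC(=O)c1ccc2c(c1)c(=O)c(C(=O)Nc1ccc(Oc3ncnc4[nH]cc(-c5ccccc5)c34)c(F)c1)c(C)n2C` is not yet measured. It differs from compound 3 by methoxycarbonyl in place of cyclopentyl on an aromatic carbon, the group sitting on an aromatic carbon of a six-membered aromatic ring of carbon only, part of a fused or bridged system of two rings.

Going by the values given here, no measured step exchanges an alkyl group for methoxycarbonyl at this carbon, so the guidance is indirect. The steps of a 6.5-fold higher number from compound 1 to compound 2 (0.82 log units; beyond the scatter) and a 7.7-fold higher number from compound 1 to compound 3 (0.89 log units; beyond the scatter) show that changing the group at this carbon can move the number beyond the scatter, whereas a 1.2-fold higher number from compound 2 to compound 3 (0.07 log units; within the scatter) shows hardly any change. Among the compounds with values here, with no closer precedent, compound 4 is expected to give 150 nM, with a range of 40 nM to 600 nM, corresponding to an estimated step of a 1.3-fold lower number from compound 3 to compound 4 (0.12 log units; within the scatter) in this assay, which may not exceed the scatter.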

Compound 4, half-maximal inhibitory concentration: > 10000 nM
Compound 4 was reported as a limit; the forecaster's own chance of this, stated with the estimate: 5%; middle value at least 66-fold (1.82 log units) away from the limit.
By their numbers in this assay, from the lowest: compound 1; then compounds 2 and 3 (each within the scatter of the next). At a limit, above all of these: compound 4.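

In this assay compound 4 is reported only as a limit and not as a number: the limit of > 10000 nM in this assay, at which 1 of the 4 values shown sits. Methoxycarbonyl in place of cyclopentyl is therefore a large step, an at least 50-fold higher number from compound 3 to compound 4 (1.69 log units; beyond the scatter), and the exchange against the other two groups is equally large, an at least 58-fold higher number from compound 2 to compound 4 (1.76 log units; beyond the scatter) and an at least 380-fold higher number from compound 1 to compound 4 (2.58 log units; beyond the scatter). The earlier compounds showed only modest movement at this aromatic carbon among groups of carbon alone, whereas methoxycarbonyl, the one group shown that carries oxygen and hydrogen-bond acceptors, takes the number out of the measurable range.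

The compounds shown leave open whether this loss follows the whole ester or only part of it, which a carboxylic acid, a primary amide or a methyl ketone at this carbon could separate. They also leave open how a methoxy group or an ethyl group would fare here.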